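A few compounds are considered here, and "the series" means these few. Any claim that something is new, unique, unknown or untested is made for them only; others in the source may bear on it.

Measured compounds:
compound 1, `Cc1cn(C2CCN(Cc3cccc(Oc4ccncc4)c3)CC2)c(=O)[nH]c1=O`: "not determined" (no result reported)
compound 2, `Cc1cn(C2CCN(Cc3cncc(Oc4ccccc4)c3)CC2)c(=O)[nH]c1=O`: > 64000 nM

Two compounds of the series have been taken into an ADME assay on MRC5 cells (Homo sapiens) for cytotoxicity, read by fluorescence and resazurin assay, with a stated time of 3 days; a higher number here means a weaker inhibitor, a lower number a stronger inhibitor; a third, compound 3 with the structure `Cc1cn(C2CCN(Cc3cccc(OC4CCCC4)c3)CC2)c(=O)[nH]c1=O`, is still to be measured. In this assay compound 1 gives "not determined" (no result reported), so no number stands for it. In this assay compound 2 gives > 64000 nM, which is a limit of the assay rather than a number. Among the measured compounds shown here, compound 1 therefore has no single number against which a step can be set, and the only further value in the set is a limit, as summed up in the limit of > 64000 nM in this assay, at which 1 of the 2 values shown sits.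

The step from compound 1 to compound 3 is a change at the ether oxygen: cyclopentyl in place of pyridin-4-yl on an oxygen on an aromatic ring. For the measured compounds named here, no measured pair shows a step of this kind, so the size of the step in this assay can only be guessed. Going by the values given here, since the one value shown sits at the assay limit, a weak cytotoxicity at or near that limit is the working expectation for the series, with no step beyond the usual scatter anticipated. Compound 3 is accordingly expected to give about 64000 nM in this assay, with a range from 20000 nM to 150000 nM, and most likely only a limit will be reported.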

Compound 3, half-maximal inhibitory concentration: 30300 nM
Beside the measured number, compound 3's estimate is 2.1-fold (0.32 log units) above it; the measured number falls inside the stated range.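

In this assay compound 3 gives 30300 nM, but no new step can be read, as compound 1 gives "not determined" (no result reported) and offers no number to compare. For compound 2 the only value is a limit: the limit of > 64000 nM in this assay, at which 1 of the 3 values shown sits.

Still open, on these data alone, is what cyclopentyl in place of pyridin-4-yl, on an oxygen on an aromatic ring, does to the value in this assay.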